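The compounds below may be only part of what the source reports. "The series", "measured", "known", "first", "only" and "open" are said of these compounds alone.

Series around the shared core of compound 1 `O=C(O)/C=C/c1ccc(NCc2cccc(Oc3ccccc3)c2)cc1`, read in a functional assay on CHO cells for agonist activity at Free fatty acid receptor 1 (Homo sapiens), read by a luciferase reporter (on this read-out higher numbers stand for larger maximal responses and lower numbers for smaller maximal responses), where compound 1 gives 76%. Compound 2 `NC(=O)CCc1ccc(NCc2cccc(Oc3ccccc3)c2)cc1` gives 68%; the step of a number 8 percentage points lower from compound 1 to compound 2 (within the scatter) leaves both within the scatter, so compound 2 stands lowest of the two numbers only nominally. Compound 3 `CN(C)C(=O)CCc1ccc(NCc2cccc(Oc3ccccc3)c2)cc1` carries dimethylamino in place of amino on a carbonyl carbon. Among the compounds with values here, no measured step alters this group, and the one measured step, a number 8 percentage points lower from compound 1 to compound 2 (within the scatter), changed the terminal group without moving the read-out beyond the scatter. The expected step is therefore estimated as a number 5 percentage points lower from compound 2 to compound 3 (within the scatter). Compound 3 is estimated at 63%, between 45% and 80%.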

Compound 3, largest response reached (reported as percent of maximum), in percent of the reference or control that the assay uses: 50%
For compound 3 the middle estimate is 13 percentage points above the measured one; measured number inside the range.
By their numbers in this assay, from the lowest: compound 3; then compounds 2 and 1 (each within the scatter of the next).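

In this assay, within the data shown here, the amide end of the chain is the first place where a change moves the response beyond the scatter: dimethylamino in place of amino on a carbonyl carbon gives a number 18 percentage points lower from compound 2 to compound 3 (beyond the scatter), while the primary amide had stayed within the scatter of the starting acid. Against compound 1, 2-(dimethylcarbamoyl)ethyl in place of 2-carboxyethenyl gives a number 26 percentage points lower from compound 1 to compound 3 (beyond the scatter), a larger step. No measurement on hand explains this loss of response.

A methylamino group on the same carbonyl carbon could show whether one methyl already carries part of the step. A 2-carboxyethyl chain could separate the acid from the chain's saturation.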